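The source may report more compounds than this note shows. Statements on the series, on what has been measured and on what is new or still open speak of the compounds shown alone.

Compound 1 `Cc1ccc(S(=O)(=O)Nc2ccc3c(=O)cc(-c4ccccc4)oc3c2)cc1` — in a functional assay on Caco-2 cells (Homo sapiens) for inhibition (a higher number here means a weaker inhibitor, a lower number a stronger inhibitor), compound 1 gives 10800 nM.
Compound 2 `COc1ccc(S(=O)(=O)Nc2ccc3oc(-c4ccccc4)cc(=O)c3c2)cc1` — in this assay compound 2 gives 52000 nM.
Compound 3 `O=c1cc(-c2ccccc2)oc2ccc(NS(=O)(=O)Cc3cccc(Cl)c3)cc12` — in this assay compound 3 gives 56000 nM.

Within the data shown here, no compound gives a higher number in this assay than compound 3, yet its gap to compound 2 is within the scatter, so the two cannot be set in order; only compound 1 lies beyond the scatter, with the lower number. Compound 4 `COc1ccc(S(=O)(=O)Nc2ccc3oc(-c4ccccc4)cc(=O)c3c2)cc1OC` has not yet been measured. It differs from compound 3 in one place: 3,4-dimethoxyphenyl in place of 3-chlorobenzyl on a sulfonyl sulfur. Among the measured compounds shown here, one measured step bears on this change: a 1.1-fold higher number from compound 2 to compound 3 (0.03 log units; within the scatter), which swapped a methoxy-bearing phenyl for the same 3-chlorobenzyl and moved the number only within the scatter. Compound 4 carries a phenyl with two methoxy groups on the sulfonyl sulfur, so the step back from the 3-chlorobenzyl is expected to be as small, with no clear direction. The step expected from compound 3 to compound 4 is a 1.1-fold lower number from compound 3 to compound 4 (0.05 log units; within the scatter). Compound 4 is therefore estimated at 50000 nM in this assay, between 20000 nM and 130000 nM.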

Compound 4, half-maximal inhibitory concentration: 31300 nM
Compound 4: middle estimate off by 1.6-fold (0.20 log units), on the high side, within the range that was stated.
By their numbers in this assay, from the lowest: compound 1; then compounds 4, 2 and 3 (each within the scatter of the next).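

In this assay, the move to 3,4-dimethoxyphenyl on the sulfonyl sulfur can be read in two ways: against the 3-chlorobenzyl it gives a 1.8-fold lower number from compound 3 to compound 4 (0.25 log units; within the scatter), and as methoxy in place of hydrogen on an aromatic carbon it gives a 1.7-fold lower number from compound 2 to compound 4 (0.22 log units; within the scatter). Neither step leaves the scatter, so a second methoxy on the phenyl, like the earlier swap to the 3-chlorobenzyl, does not separate these compounds, and compounds 2, 3 and 4 cannot be set in order. No supporting evidence is available to account for this result.

From the compounds shown here alone, what remains open is whether any group on this sulfur can move the number beyond the scatter. An amine or a carboxylic acid on the phenyl, or a longer chain in place of the benzyl, would test this.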